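Swapping Chloro for Methoxy in Compound 2

A few compounds are considered here, and "the series" means these few. Any claim that something is new, unique, unknown or untested is made for them only; others in the source may bear on it.

For the measured compounds named here, compound 2 `COc1ccc(S(=O)(=O)c2cnc3c(F)cccc3c2-c2ccc(Cl)cc2)cc1` gives 1.05 mL/min in an ADME assay on microsomes from liver (Homo sapiens) for metabolic stability, tested at 2.5 uM (a higher number here means faster removal of the compound, a lower number slower removal), the highest of the three numbers measured so far. Compound 3 `O=S(=O)(c1cc(F)cc(F)c1)c1cnc2c(F)cccc2c1-c1ccc(Cl)cc1` gives 0.73 mL/min; taken as a step this is a 1.4-fold lower number from compound 2 to compound 3 (0.16 log units; within the scatter). Compound 1 `O=S(=O)(c1ccc(F)c(F)c1)c1cnc2c(F)cccc2c1-c1ccc(Cl)cc1` gives 0.28 mL/min, and from there the steps are a 3.8-fold higher number from compound 1 to compound 2 (0.57 log units; beyond the scatter) and a 2.6-fold higher number from compound 1 to compound 3 (0.42 log units; beyond the scatter). Compound 4 `COc1ccc(-c2c(S(=O)(=O)c3ccc(OC)cc3)cnc3c(F)cccc23)cc1` differs from compound 2 by methoxy in place of chloro on an aromatic carbon. Going by the values given here, no measured step changes that part of the molecule; the nearest comparison is a 3.8-fold higher number from compound 1 to compound 2 (0.57 log units; beyond the scatter), which also brought in a methoxy group, there on the sulfonyl sulfur. The expected step is therefore a modest rise, a 1.4-fold higher number from compound 2 to compound 4 (0.15 log units; within the scatter), though one that could still fall within the scatter. Compound 4 is estimated at 1.5 mL/min, with a range from 0.7 mL/min to 3.2 mL/min.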

Compound 4, intrinsic clearance in a liver preparation (reported as CLH), per the amount of preparation that the assay uses: 2.12 mL/min
Estimate against measurement, compound 4: 1.4-fold (0.15 log units) below; the range from low to high includes it.
By their numbers in this assay, from the lowest: compound 1; then compounds 3 and 2 (each within the scatter of the next); then compound 4.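

For the compounds shown here, the earlier steps all changed the group on the sulfonyl sulfur, so this is the first view of the 4-chlorophenyl side. In this assay, methoxy in place of chloro on an aromatic carbon gives a 2.0-fold higher number from compound 2 to compound 4 (0.31 log units; beyond the scatter), so a modest change at this position also moves the read-out. Nothing at hand explains the rise.

A single change here cannot show how other groups at this position, such as a nitrile or an amine, would behave. Going by these compounds, whether the step would hold with the 3,4-difluorophenyl of compound 1 on the sulfonyl sulfur also stays open.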